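The source may report more compounds than this note shows. Statements on the series, on what has been measured and on what is new or still open speak of the compounds shown alone.

In a physicochemical assay, read by spectrophotometry (on this read-out lower numbers stand for stronger inhibition and higher numbers for weaker inhibition), three compounds have been measured:

Compound 1 `CN(C)c1ccc(/C=C/C(=O)/C(CNc2cccc(C(F)(F)F)c2)=C(O)/C=C/c2ccc(N(C)C)cc2)cc1` gives 81.7 ug/mL.
Compound 2 `COc1cc(C=C(C(=O)/C=C/c2ccc(N(C)C)cc2)C(=O)/C=C/c2ccc(N(C)C)cc2)ccc1O` gives 75.4 ug/mL.
Compound 3 `COc1ccc(-n2nc(/C=C/c3ccc(N(C)C)cc3)cc2/C=C/c2ccc(N(C)C)cc2)cc1` gives 88.1 ug/mL.

Compound 3 sits at the top end of these three figures, but the gaps to compound 1 and to compound 2 both fall within the usual scatter, so the three cannot be told apart on this evidence. Compound 4 `CN(C)c1ccc(/C=C/c2cc(/C=C/c3ccc(N(C)C)cc3)n(-c3ccc(F)cc3)n2)cc1` differs from compound 3 in a single spot: fluoro in place of methoxy on an aromatic carbon. Cut one bond further out, the change reads 4-methoxyphenyl to 4-fluorophenyl, with the group sitting para to a large group on a six-membered aromatic ring of carbon only. Going by the values given here, no pair of measured compounds differs in just one place, so there is no measured step to lean on. With the three values so close together and the rest of the molecule unchanged, the step from compound 3 to compound 4 is expected to stay within the scatter, in no firm direction, with a 1.0-fold lower number from compound 3 to compound 4 (0.02 log units; within the scatter). Compound 4 is therefore estimated at 85 ug/mL, in the range 50 ug/mL to 145 ug/mL.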

Compound 4, half-maximal inhibitory concentration: 74.4 ug/mL
The estimate for compound 4 lay 1.1-fold (0.06 log units) above the measured number; measured number inside the range.
By their numbers in this assay, from the lowest: compounds 4, 2, 1 and 3 (each within the scatter of the next).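

Going by these compounds alone, this is the one measured step here that changes a single place. In this assay, fluoro in place of methoxy on an aromatic carbon, para to a large group, gives (a 1.2-fold lower number from compound 3 to compound 4 (0.07 log units; within the scatter)). At this position, the read-out therefore does not separate the two groups, even though the methoxy brings two heavy atoms and a hydrogen-bond acceptor while the fluoro brings one heavy atom and no acceptor, and no measurement at hand bears on why the two read alike.

Going by these compounds, whether an amine, a carboxylic acid or a longer alkoxy chain on this same carbon would move the number beyond the scatter remains open. Also open, on these data alone, is whether fluoro and methoxy would read alike at other places on this six-membered ring.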